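From furan-2-yl to thiophen-3-yl at the assay limit

The compounds below may be only part of what the source reports. "The series", "measured", "known", "first", "only" and "open" are said of these compounds alone.

Measured in a functional assay on CEM-DNR-bulk cells (Homo sapiens), read by MTT assay, with a stated time of 72 h; a higher number here means a weaker inhibitor, a lower number a stronger inhibitor:
Compound 1 `Nc1nc(N)c2c(-c3ccco3)cn([C@@H]3O[C@H](CO)[C@@H](O)[C@H]3O)c2n1`: > 20000 nM (a limit)
Compound 2 `COc1nc(N)nc2c1c(-c1ccco1)cn2[C@@H]1O[C@H](CO)[C@@H](O)[C@H]1O`: > 20000 nM (a limit)

Neither entry is a number. Compound 2 stands at > 20000 nM, which is a limit. For the measured compounds named here, it shares that position with the only other measured compound, as the record shows: the limit of > 20000 nM in this assay, at which 2 of the 2 values shown sit.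

Compound 3 `COc1nc(N)nc2c1c(-c1ccsc1)cn2[C@@H]1O[C@H](CO)[C@@H](O)[C@H]1O` differs from compound 2 in one group, with thiophen-3-yl in place of furan-2-yl on an aromatic carbon.

Going by the values given here, only one measured step exists, a step that the two limits leave unreadable from compound 1 to compound 2. Among the compounds with values here, its size cannot be read, and it concerns a different place on the molecule, so no measured step speaks directly to this exchange. In this assay no step beyond the scatter is therefore expected, and no direction can be given. The expected step is a number no higher from compound 2 to compound 3 (the limit leaves the size open). Compound 3 will quite possibly return only a limit as well. For compound 3 the estimated value is 20000 nM, with an expected range from 5000 nM to 40000 nM.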

Compound 3, half-maximal inhibitory concentration: > 20000 nM
Compound 3 was reported as a limit; the forecaster's own chance of this, stated with the estimate: 75%; the middle value sits exactly at the limit.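

In this assay compound 3 gives > 20000 nM, which is a limit and not a number. With compound 2 also recorded as a limit, no step can be read between compound 2 and compound 3. The compounds shown leave open how compound 1, compound 2 and compound 3 rank against one another, and whether either exchange alters potency at all: the limit of > 20000 nM in this assay, at which 3 of the 3 values shown sit.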